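This account rests on a few compounds, and the source may have more. Where it says the series, first, only, none or still open, it means among the compounds named here.

Measured compounds:
compound 1 `COC(=O)[C@@]1(C)CCC=C2[C@@H]1CC[C@@H](C)[C@]2(C)Cc1c[nH]c2ccc(C)cc12` gives 20000 nM
compound 2 `COC(=O)[C@@]1(C)CCC=C2[C@@H]1CC[C@@H](C)[C@]2(C)Cc1c[nH]c2ccc(Br)cc12` gives 16000 nM
compound 3 `COC(=O)[C@@]1(C)CCC=C2[C@@H]1CC[C@@H](C)[C@]2(C)Cc1c(C)[nH]c2c(C)cccc12` gives 19000 nM

All three values come from a functional assay on T47D cells (Homo sapiens) for inhibition, read by sulforhodamine B assay, with a stated time of 48 h; a lower number here means a stronger inhibitor of growth, a higher number a weaker inhibitor of growth. Compound 1 and compound 2 share a core and differ in one place, (bromo in place of methyl on an aromatic carbon); that change gave a 1.3-fold lower number from compound 1 to compound 2 (0.10 log units; within the scatter). Compound 3 has a different core, and the difference between the two cores is not broken down here; its value and those of compound 1 and compound 2 all lie within the scatter of one another.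

Compound 4 `COC(=O)[C@@]1(C)CCC=C2[C@@H]1CC[C@@H](C)[C@]2(C)Cc1c(C)[nH]c2c(Br)cccc12` is not yet measured. It differs from compound 3 by bromo in place of methyl on an aromatic carbon, the same kind of change as from compound 1 to compound 2, though the place is not the same: there the bromo sat meta to a fused ring and para to a fused ring, here it sits ortho to a fused ring and meta to a fused ring. Because the earlier step was a 1.3-fold lower number from compound 1 to compound 2 (0.10 log units; within the scatter), the step in this assay is expected to be small as well, about a 1.2-fold lower number from compound 3 to compound 4 (0.07 log units; within the scatter). Compound 4 is therefore estimated at 16000 nM, most likely between 8000 nM and 32000 nM.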

Compound 4, concentration for 50% growth inhibition: 31000 nM
Estimate against measurement, compound 4: 1.9-fold (0.29 log units) below, within the range that was stated.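

Bromo in place of methyl on an aromatic carbon, tested in this assay, gave a 1.6-fold higher number from compound 3 to compound 4 (0.21 log units; within the scatter). Set beside the earlier step, the result on this second core does not differ beyond what repeat measurements would allow: the same change on two cores in this assay, a 1.3-fold lower number (0.10 log units; within the scatter) from compound 1 to compound 2 and a 1.6-fold higher number (0.21 log units; within the scatter) from compound 3 to compound 4, 2.0-fold (0.31 log units) apart, within the scatter of two such steps. This shows that the change stayed small on both cores, but it does not show that the two steps are truly equal or that they point the same way, as each rests on a single pair, the bromo sits at a different place in each pair, and neither step stands clear of the scatter.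

The compounds shown carry only methyl or bromo on the six-membered aromatic ring, leaving open whether a different group there, such as an amine, a carboxylic acid or a longer chain, would move the number beyond the scatter. Going by these compounds, it also remains open how the growth inhibition would respond if the methyl ester shared by all four compounds were replaced by a carboxylic acid or an amide.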